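Mirror-image pair in the methoxypyridine series

The source may hold more compounds than are shown below. What is called first, only, known or untested is meant among the compounds shown, and "the series" means these compounds.

Compound 2 (`COc1ccc(N2CC[C@H]3CN[C@H]3C2)cn1`) gives 1100 nM in a functional assay on HEK293 cells for agonist activity at Neuronal acetylcholine receptor; alpha3/beta4 (Homo sapiens), read by FLIPR (on this read-out higher numbers stand for an effect only at larger amounts of compound and lower numbers for an effect already at smaller amounts), the highest of the two numbers to hand, while compound 1 (`Clc1ccc(N2CC[C@@H]3CN[C@@H]3C2)cn1`) gives 25 nM in this assay. Compound 3 (`COc1ccc(N2CC[C@@H]3CN[C@@H]3C2)cn1`) is not yet measured. Between compound 2 and compound 3 (the two compounds have the same atoms and bonds and differ only in configuration as drawn: 2 of 2 stereo elements differ (all stereocentres are inverted: mirror images); a stereocentre at a saturated ring carbon is drawn S in compound 2 and R in compound 3; a stereocentre at a saturated ring carbon is drawn R in compound 2 and S in compound 3). Among the compounds with values here, no measured pair shows this step, so its size is unknown, and a change beyond the scatter in either direction is possible. A lower number is expected here, given that compound 1 gives 25 nM. The estimate for compound 3 is 150 nM, expected between 30 nM and 700 nM, a step of a 7.3-fold lower number from compound 2 to compound 3 (0.87 log units; beyond the scatter).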

Compound 3, half-maximal effective concentration: 2400 nM
Estimate against measurement, compound 3: 16-fold (1.20 log units) below; measured number above the stated range.
By their numbers in this assay, from the lowest: compound 1; then compound 2; then compound 3.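

In this assay, inverting both stereocentres gives a 2.2-fold higher number from compound 2 to compound 3 (0.34 log units; beyond the scatter), a modest step, and configuration is the only difference available to account for it: the fact that compounds 2 and 3 differ only in the configuration as drawn. With configuration held, methoxy in place of chloro on the aromatic carbon gives a 96-fold higher number from compound 1 to compound 3 (1.98 log units; beyond the scatter), a large step and the first matched read on this position, with chloro carrying the lower number.

From the compounds shown here alone, whether the mirror-image step keeps its size in the chloro compounds remains open. Also open, going by these compounds, is how fluoro, methyl or an amine at this aromatic carbon would stand against chloro and methoxy.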